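The compounds below may be only part of what the source reports. "The series", "measured", "known", "first", "only" and "open" are said of these compounds alone.

In a functional assay on MM1.S cells (Homo sapiens) for cytotoxicity, read by MTT assay, with a stated time of 48 h (on this read-out lower numbers stand for stronger inhibition and higher numbers for weaker inhibition), three compounds built on one shared core have been measured. Compound 1 `Cc1cccc(NN=C2C(Cl)=C(Cl)C(Cl)=C2Cl)c1` reaches only a limit of the assay, > 3000 nM. Compound 2 `Fc1cccc(NN=C2C(Cl)=C(Cl)C(Cl)=C2Cl)c1` gives 1500 nM, and compound 3 `O=C(c1ccc(F)cc1)N(N=C1C(Cl)=C(Cl)C(Cl)=C1Cl)C(=O)c1ccc(F)cc1` gives 300 nM. Among the compounds with values here, of the two numbers known, compound 2 stands highest; the gap down to compound 3 lies beyond the usual scatter, while the value of compound 1 is a limit and not a number. Within the data shown here, the only single-point step measured so far is an at least 2.0-fold lower number from compound 1 to compound 2 (0.30 log units; that floor lies within the scatter), and that floor lies within the scatter, so it shows little more than that the number did not rise.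

Compound 4 `ClC1=C(Cl)C(Cl)=C(Cl)C1=NNc1ccccc1` differs from compound 2 by hydrogen in place of fluoro on an aromatic carbon. The step from compound 1 to compound 2 bears on this change, as it concerns the same aromatic carbon, but it sets only a floor inside the scatter and gives no firm direction. Compound 4 carries neither the methyl of compound 1 nor the fluoro of compound 2, so a modest rise in the number, or no step beyond the scatter, is expected in this assay. Compound 4 is therefore expected to give about 2500 nM, between 1000 nM and 6000 nM. That amounts to an expected step of a 1.7-fold higher number from compound 2 to compound 4 (0.22 log units; within the scatter).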

Compound 4, half-maximal inhibitory concentration: 2000 nM
Compound 4: middle estimate off by 1.3-fold (0.10 log units), on the high side, and the stated range covers the measured number.
By their numbers in this assay, from the lowest: compound 3; then compounds 2 and 4 (each within the scatter of the next). At a limit, above all of these: compound 1.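

In this assay, the aromatic carbon that carried methyl in compound 1 and fluoro in compound 2 now has its plain reference, hydrogen, in compound 4. Hydrogen in place of fluoro gives a 1.3-fold higher number from compound 2 to compound 4 (0.12 log units; within the scatter), so at this position, meta to a large group, these two substituents cannot be told apart, while hydrogen in place of methyl gives only a floor, an at least 1.5-fold lower number from compound 1 to compound 4 (0.17 log units; that floor lies within the scatter). Compound 1 stands at a limit and not at a number, so the comparison of methyl with hydrogen still has no firm direction: the limit of > 3000 nM in this assay, at which 1 of the 4 values shown sits.

The compounds shown leave open whether any group on this aromatic carbon can move the number beyond the scatter, a question that an amine, a carboxylic acid or a methoxy group there would address. They also leave open which feature lies behind the lower number of compound 3, 300 nM, since compound 3 differs from the other compounds in more than one place and no single change can be tied to its value.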